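Series notes: cyano to pyridin-3-yl, estimate for compound 3

A few compounds are considered here, and "the series" means these few. Any claim that something is new, unique, unknown or untested is made for them only; others in the source may bear on it.

Two compounds in the series have numbers. Compound 1 `CCC(CC)CNc1c(C(N)=O)cnc2ccc(C#N)cc12` gives 8 nM in an assay on isolated protein for inhibition of Serine-protein kinase ATM (Homo sapiens), read by HTRF, with stated times of 30 min and 2 h, in the presence of a further agent that is not named here; a higher number here means a weaker inhibitor, a lower number a stronger inhibitor. Compound 2 `C[C@@H](Nc1c(C(N)=O)cnc2ccc(C#N)cc12)c1ccc(Cl)cc1` gives 49 nM in this assay, the higher of the two numbers. Compound 3 `C[C@@H](Nc1c(C(N)=O)cnc2ccc(-c3cccnc3)cc12)c1ccc(Cl)cc1` is not yet measured; it differs from compound 2 by pyridin-3-yl in place of cyano on an aromatic carbon. Among the measured compounds shown here, no step between measured compounds sets the size of such a change, so any expectation rests on compound 2 alone. The number is expected to move downward by a modest amount, possibly no further than the scatter, as an expected step of a 1.6-fold lower number from compound 2 to compound 3 (0.21 log units; within the scatter). Compound 3 is estimated at 30 nM, within 8 nM to 120 nM.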

Compound 3, half-maximal inhibitory concentration: 2 nM
Compound 3: the middle estimate sits 15-fold (1.18 log units) above what was measured; measured number below the stated range.
By their numbers in this assay, from the lowest: compound 3; then compound 1; then compound 2.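

In this assay, the aromatic carbon that carries cyano in compound 2 also accepts a whole six-membered aromatic ring: pyridin-3-yl gives a 25-fold lower number from compound 2 to compound 3 (1.39 log units; beyond the scatter) and so lies well beyond the scatter. Among the compounds shown here, this is the first measured change at this place, and it shows that the position strongly affects the number. Nothing on hand accounts for the size of the step.

Going by these compounds, it remains open whether the ring nitrogen matters, which phenyl or pyridin-4-yl here would test. On these data alone, it is also open whether the gain carries over to the side chain of compound 1.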